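A Cytotoxicity Limit Carried from Compound 3 to Compound 4

The source may hold more compounds than are shown below. What is called first, only, known or untested is meant among the compounds shown, and "the series" means these compounds.

Compound 3 `Cc1ccc2[nH]c(=O)c(CN(Cc3ccc(SC(F)F)cc3)Cc3ccc(C(C)(C)C)cc3)cc2c1` stands only at a limit in a toxicity assay on MDCK cells (Canis lupus familiaris) for cytotoxicity, read by crystal violet staining, with a stated time of 48 h; a higher number here means that more compound is tolerated, a lower number that less compound is tolerated: compound 3 gives > 5000 nM, which is a limit of the assay. Compound 1 `Cc1ccc2[nH]c(=O)c(CN(Cc3ccc(F)cc3)Cc3ccc(C(C)(C)C)cc3)cc2c1` likewise gives > 27000 nM, a limit. Compound 2 `CCCOc1ccc(CN(Cc2ccc(C(C)(C)C)cc2)Cc2cc3cc(C)ccc3[nH]c2=O)cc1` gives > 5000 nM, also a limit. One of the three values sits at the limit of > 27000 nM in this assay, at which 1 of the 3 values shown sits, and two at the limit of > 5000 nM in this assay, at which 2 of the 3 values shown sit. The steps a step that the two limits leave unreadable from compound 1 to compound 2, a step that the two limits leave unreadable from compound 1 to compound 3 and a step that the two limits leave unreadable from compound 2 to compound 3 are therefore unreadable in size. Compound 4 `Cc1ccc2[nH]c(=O)c(CN(Cc3ccc(C(C)(C)C)cc3)C(C)c3ccc(OC(F)F)cc3)cc2c1` differs from compound 3 by 1-(4-(difluoromethoxy)phenyl)ethyl in place of 4-((difluoromethyl)sulfanyl)benzyl on an amine nitrogen. Going by the values given here, none of the measured steps reads on this change, so no direction can be drawn from them. Compound 4 is expected to remain tolerated across the tested range. The step that the limit leaves unreadable from compound 3 to compound 4 is expected to be small. Compound 4 is estimated at 10000 nM, within 3000 nM to 40000 nM.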

Compound 4, half-maximal cytotoxic concentration: > 5000 nM
Compound 4 ended at the assay's limit (the forecaster's own chance of this, stated with the estimate: 75%); the middle value lies beyond the limit too.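

Compound 4 also stands at a limit, so its steps from compound 1, compound 2 and compound 3 cannot be read. The compounds shown leave open what concentration of any of these four marks half-maximal cytotoxicity in this assay.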